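A few compounds are considered here, and "the series" means these few. Any claim that something is new, unique, unknown or untested is made for them only; others in the source may bear on it.

Measured so far:
compound 1 `CCOC(=O)C1=C(N/N=C(/C#N)C(=O)OCC)Nc2[nH]nc(C)c2C1c1ccc(N(C)C)cc1` gives 39200 nM
compound 2 `CCOC(=O)C1=C(N/N=C(\C#N)C(N)=O)Nc2[nH]nc(C)c2C1c1ccc(N(C)C)cc1` gives 47300 nM
compound 3 `CCOC(=O)C1=C(N)Nc2[nH]nc(C)c2C1c1ccc(N(C)C)cc1` gives 6220 nM

In a functional assay on HeLa cells (Homo sapiens) for inhibition, read by MTT assay, with a stated time of 48 h (a lower number here means a stronger inhibitor, a higher number a weaker inhibitor), compound 3 has the lowest number of the three, which makes it the strongest inhibitor of this small set. Compound 4 `CCOC(=O)C1=C(N/N=C(/C(C)=O)C(=O)OCC)Nc2[nH]nc(C)c2C1c1ccc(N(C)C)cc1` differs from compound 3 in one place (a group of 10 heavy atoms (6 carbon, 1 nitrogen, 3 oxygen; no ring) in place of a hydrogen atom, on an amine nitrogen) and so gains a chain where compound 3 has only a hydrogen atom.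

Among the compounds with values here, two measured steps bear on this, and both take a chain off an amine nitrogen (a 6.3-fold lower number from compound 1 to compound 3 (0.80 log units; beyond the scatter)) and (a 7.6-fold lower number from compound 2 to compound 3 (0.88 log units; beyond the scatter)). Each step is modest but beyond the scatter. The step between the two chain-bearing compounds (a 1.2-fold higher number from compound 1 to compound 2 (0.08 log units; within the scatter)) stays within the scatter, so the two chains tested so far do not separate.

Compound 4 adds a chain of comparable size, so a step of similar size in the reverse direction is expected, towards a weaker inhibitor. This rests on compound 1 (39200 nM) and compound 2 (47300 nM). The estimated step (a 6.4-fold higher number from compound 3 to compound 4 (0.81 log units; beyond the scatter)) is upward. For compound 4 the expected value is 40000 nM within an estimated range of 18000 nM to 85000 nM in this assay.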

Compound 4, half-maximal inhibitory concentration: > 100000 nM
Compound 4: only a limit was reported; the forecaster's own chance of this, stated with the estimate: 15%; at least 2.5-fold (0.39 log units) between middle value and limit.
By their numbers in this assay, from the lowest: compound 3; then compounds 1 and 2 (each within the scatter of the next). At a limit, above all of these: compound 4.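

In this assay compound 4 gives > 100000 nM, which is a limit and not a number. The chains on this amine nitrogen now separate: the two earlier chains did not, with a 1.2-fold higher number from compound 1 to compound 2 (0.08 log units; within the scatter), but acetyl in place of cyano gives an at least 2.5-fold higher number from compound 1 to compound 4 (0.40 log units; beyond the scatter), and the chain with the amide gives an at least 2.1-fold higher number from compound 2 to compound 4 (0.32 log units; beyond the scatter). So what the chain carries matters here and not only whether a chain is present, and the widest gap is to the bare hydrogen, with an at least 16-fold higher number from compound 3 to compound 4 (1.20 log units; beyond the scatter).

As far as these compounds go, how far compound 4 really lies from the other compounds stays unknown, since only its limit is available. Also open, from the compounds shown here alone, is whether a much smaller group on this nitrogen, such as a methyl or a single acetyl, would stay close to compound 3 or move towards the chain-bearing compounds.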